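Trading an aromatic arm for 2-(pyrrolidin-1-yl)ethyl

A few compounds are considered here, and "the series" means these few. Any claim that something is new, unique, unknown or untested is made for them only; others in the source may bear on it.

In a functional assay on U-87MG ATCC cells (Homo sapiens) for antiproliferative activity, with a stated time of 3 days (a lower number here means that less compound is needed, a higher number that more compound is needed for the effect), compound 1 (`Oc1ccc(CN(Cc2cccc(C(F)(F)F)c2)Cc2ccc(O)c3ncccc23)c2cccnc12`) gives 2 uM and compound 2 (`Oc1ccc(CN(Cc2cccc(I)c2)Cc2ccc(O)c3ncccc23)c2cccnc12`) gives 2 uM, which together are the lowest of the three measured numbers. The exchange between them, iodo for trifluoromethyl, shows no change at the digits printed from compound 1 to compound 2 (within the scatter). Compound 4 (`Oc1ccc(CN(CCN2CCCC2)Cc2ccc(O)c3ncccc23)c2cccnc12`) has (pyrrolidin-1-yl)methyl in place of 3-(trifluoromethyl)phenyl on a saturated chain carbon bound to an amine nitrogen. For the measured compounds named here, the nearest precedent is compound 3 (`Oc1ccc(CN(Cc2ccc(O)c3ncccc23)CC2CCCO2)c2cccnc12`), which has oxolan-2-yl at that place and gives 5 uM. Losing the aromatic ring there gave a 2.5-fold higher number from compound 1 to compound 3 (0.40 log units; beyond the scatter) and a 2.5-fold higher number from compound 2 to compound 3 (0.40 log units; beyond the scatter). Going by the values given here, no measured compound carries pyrrolidin-1-yl, so the precedent is only partial. A similar modest step is expected, namely a 2.0-fold higher number from compound 1 to compound 4 (0.30 log units; within the scatter). For compound 4 the estimate is 4 uM, with an expected range of 1.5 uM to 10 uM.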

Compound 4, concentration for half-maximal effect: 0.2 uM
Compound 4: middle estimate off by 20-fold (1.30 log units), on the high side; the whole stated range lies above it.
By their numbers in this assay, from the lowest: compound 4; then compounds 1 and 2 (each within the scatter of the next); then compound 3.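

In this assay, for the compounds shown here, the earlier compounds tied loss of the aromatic ring at this saturated chain carbon to a higher number, yet 2-(pyrrolidin-1-yl)ethyl gives a 10-fold lower number from compound 1 to compound 4 (1.00 log units; beyond the scatter) and a 10-fold lower number from compound 2 to compound 4 (1.00 log units; beyond the scatter) so an aromatic arm is not required here. What replaces it decides the outcome, as the comparison of the two non-aromatic arms shows (a 25-fold lower number from compound 3 to compound 4 (1.40 log units; beyond the scatter)). Nothing available explains this gain. Still open, on these data alone, is whether the gain belongs to the pyrrolidine ring or to any amine on this chain. A piperidine, a morpholine, an open-chain dimethylamino group or a longer chain at this place would separate those readings.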